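Bromo for trifluoromethyl on the triazole-linked aryl

A few compounds are considered here, and "the series" means these few. Any claim that something is new, unique, unknown or untested is made for them only; others in the source may bear on it.

In a functional assay on A549 cells (Homo sapiens) for cytotoxicity, read by MTT assay, with a stated time of 4 days (on this read-out lower numbers stand for stronger inhibition and higher numbers for weaker inhibition), compound 1 `C=C1C[C@]23C[C@@]1(O)CC[C@H]2c1ccc(OS(=O)(=O)c2ccc(C)cc2)c(C)c1[C@@H]3Cn1cc(-c2ccc(Br)cc2)nn1` gives > 20000 nM, a limit of the assay rather than a number. Among the measured compounds shown here, compound 2 `C=C1C[C@]23C[C@@]1(O)CC[C@H]2c1ccc(O)c(C)c1[C@@H]3Cn1cc(-c2ccc(C(F)(F)F)cc2)nn1` gives 10400 nM in this assay, the only number in hand for the series. The other value is the limit of > 20000 nM in this assay, at which 1 of the 2 values shown sits. Compound 3 `C=C1C[C@]23C[C@@]1(O)CC[C@H]2c1ccc(O)c(C)c1[C@@H]3Cn1cc(-c2ccc(Br)cc2)nn1` differs from compound 2 by bromo in place of trifluoromethyl on an aromatic carbon. For the measured compounds named here, no measured step of this kind exists here, so the expected change is none beyond the usual scatter, in either direction. Compound 3 is estimated at 10000 nM, with a range from 4000 nM to 25000 nM, an expected step of a 1.0-fold lower number from compound 2 to compound 3 (0.02 log units; within the scatter).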

Compound 3, half-maximal inhibitory concentration: > 20000 nM
Compound 3: no number, only a limit; the forecaster's own chance of this, stated with the estimate: 30%; middle value at least 2.0-fold (0.30 log units) away from the limit.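

Compound 3 stands only at a limit of the assay, > 20000 nM. In this assay, going from 4-(trifluoromethyl)phenyl to 4-bromophenyl gives an at least 1.9-fold higher number from compound 2 to compound 3 (0.28 log units; that floor lies within the scatter), so bromo shows no gain at this position, and the true size of the step stays hidden. The step for hydrogen in place of (4-methylphenyl)sulfonyl cannot be read, as both values are limits.

Among the compounds shown here, only one compound here carries a number to compare against: the limit of > 20000 nM in this assay, at which 2 of the 3 values shown sit. Open is whether an amine or a carboxylic acid in place of bromo would bring a reading inside the limit.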